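Swapping the Sulfonamide for a Hydroxyethyl Sulfone

A few compounds are considered here, and "the series" means these few. Any claim that something is new, unique, unknown or untested is made for them only; others in the source may bear on it.

Of the compounds shown here, three built on one shared core have been measured in an assay on CHO cells for displacement of a labelled ligand from prostaglandin D2 receptor 2 (Homo sapiens), read by scintillation counting; on this read-out lower numbers stand for stronger inhibition and higher numbers for weaker inhibition. Compound 1 `COCCN(C)S(=O)(=O)c1ccc(C)c(C#Cc2cc(Cl)ccc2OCC(=O)O)c1` gives 4.1 nM. Compound 2 `Cc1ccc(S(=O)(=O)Cc2ccccc2)cc1C#Cc1cc(Cl)ccc1OCC(=O)O` gives 5 nM, and compound 3 `CNS(=O)(=O)c1ccc(C)c(C#Cc2cc(Cl)ccc2OCC(=O)O)c1` gives 10 nM. Compound 3 thus stands at the top of the three numbers, although its gap to compound 2, a 2.0-fold higher number from compound 2 to compound 3 (0.30 log units; within the scatter), lies within the scatter; only its gap to compound 1, a 2.4-fold higher number from compound 1 to compound 3 (0.39 log units; beyond the scatter), is a modest step beyond it.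

Compound 4 `Cc1ccc(S(=O)(=O)CCO)cc1C#Cc1cc(Cl)ccc1OCC(=O)O` has not yet been measured. Its difference from compound 3 is 2-hydroxyethyl in place of methylamino on a sulfonyl sulfur. Two measured steps also alter the group on the sulfonyl sulfur: a 1.2-fold higher number from compound 1 to compound 2 (0.09 log units; within the scatter) and a 2.0-fold higher number from compound 2 to compound 3 (0.30 log units; within the scatter). Both stay within the scatter, and even the combined step a 2.4-fold higher number from compound 1 to compound 3 (0.39 log units; beyond the scatter) is only modest. Different groups on the sulfonyl sulfur have therefore left the numbers close together, and nothing in these three compounds points to a large move in either direction.

The step expected for compound 4 is a 1.3-fold lower number from compound 3 to compound 4 (0.10 log units; within the scatter), a change no larger than the scatter itself. Compound 4 is therefore estimated to give about 8 nM in this assay, with a likely range from 3 nM to 25 nM.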

Compound 4, inhibition constant: 19 nM
Estimate against measurement, compound 4: 2.4-fold (0.38 log units) below, and the stated range covers the measured number.
By their numbers in this assay, from the lowest: compounds 1, 2, 3 and 4 (each within the scatter of the next, the first and the last beyond it).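

In this assay, exchanging the methylsulfamoyl group for (2-hydroxyethyl)sulfonyl, which puts a carbon chain rather than a nitrogen on the sulfonyl sulfur, gives only a 1.9-fold higher number from compound 3 to compound 4 (0.28 log units; within the scatter), so this single change does not separate the two compounds. Within the data shown here, the new compound does widen the spread at this position, where only one earlier step had passed the scatter: hydroxymethyl in place of phenyl gives a 3.8-fold higher number from compound 2 to compound 4 (0.58 log units; beyond the scatter), and the exchange with the larger (2-methoxyethyl)(methyl)amino group gives a 4.6-fold higher number from compound 1 to compound 4 (0.67 log units; beyond the scatter), both modest but beyond the scatter. No measurement offered here explains why the numbers fall this way.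

Going by these compounds, it remains open what a plain ethyl group, with no hydroxyl at its end, would give on the same sulfonyl sulfur, and so whether the hydroxyl of compound 4 makes any difference to the number. Also open, on these data alone, are a longer chain such as 3-hydroxypropyl and a chain ending in an amine, such as 2-aminoethyl, either of which would show how far this sulfone series can be varied.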